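The compounds below may be only part of what the source reports. "The series", "measured", "known", "first", "only" and "open" are said of these compounds alone.

Measured compounds:

compound 1, `CC1=NNC(=O)C1C(c1c(-c2ccccc2)[nH]c2ccc(Cl)cc12)c1c(-c2ccccc2)[nH]c2ccc(Cl)cc12`, 9500 nM
compound 2, `COc1ccc2[nH]c(-c3ccccc3)c(C(c3c(-c4ccccc4)[nH]c4ccc(Cl)cc34)C3C(=O)NN=C3C)c2c1`, 1200 nM
compound 3, `CC1=NNC(=O)C1C(c1c[nH]c2ccccc12)c1c(-c2ccccc2)[nH]c2ccc(Cl)cc12`, 3800 nM

All three were tested in a functional assay on HeLa cells (Homo sapiens) for cytotoxicity, read by MTT assay; on this read-out lower numbers stand for stronger inhibition and higher numbers for weaker inhibition. In this assay compound 1 gives 9500 nM and compound 2 gives 1200 nM. The two differ in one place, (methoxy in place of chloro on an aromatic carbon), and that change made a step of a 7.9-fold lower number from compound 1 to compound 2 (0.90 log units; beyond the scatter). Compound 3 carries a different core, and the difference between the core of compound 3 and the core of compound 1 is not broken down here; in this assay compound 3 gives 3800 nM, which lies between the other two values.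

Compound 4, `COc1ccc2[nH]c(-c3ccccc3)c(C(c3c[nH]c4ccccc34)C3C(=O)NN=C3C)c2c1`, has not yet been measured. It stands to compound 3 as compound 2 stands to compound 1: the change is methoxy in place of chloro on an aromatic carbon, and the surroundings of the changed position read the same in both pairs, so it is the same change made on a second core. Among the compounds with values here, the only guide to its size is the single measured step, a 7.9-fold lower number from compound 1 to compound 2 (0.90 log units; beyond the scatter), and because that step is a 7.9-fold lower number from compound 1 to compound 2 (0.90 log units; beyond the scatter) the expectation is that compound 4 will again come out with a lower number than compound 3. The step is expected to be a 4.8-fold lower number from compound 3 to compound 4 (0.68 log units; beyond the scatter), kept a little smaller than the measured one since it rests on one pair only. Compound 4 is therefore estimated at 800 nM, with a range from 300 nM to 2500 nM.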

Compound 4, half-maximal inhibitory concentration: 1700 nM
Beside the measured number, compound 4's estimate is 2.1-fold (0.33 log units) below it; measured number inside the range.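

In this assay, methoxy in place of chloro on an aromatic carbon again lowered the number on the second core, with a 2.2-fold lower number from compound 3 to compound 4 (0.35 log units; beyond the scatter). Within the data shown here, the direction of the change carried over from one core to the other, but its size did not, as the two steps set side by side show: the same change on two cores in this assay, a 7.9-fold lower number (0.90 log units; beyond the scatter) from compound 1 to compound 2 and a 2.2-fold lower number (0.35 log units; beyond the scatter) from compound 3 to compound 4, 3.5-fold (0.55 log units) apart, beyond the scatter of two such steps This shows that, within these two pairs, the size of the step measured on one core cannot simply be transferred to the other, but with only two pairs it does not show which feature of the cores sets the size, or why the steps differ.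

The compounds shown carry only chloro or methoxy at the changed place, so it remains open how a hydroxyl group, an amine or a carboxylic acid there would behave on either core. From the compounds shown here alone, it also remains open whether the change would lower the number on a third core, and whether the same steps would appear in cell lines other than the one used here.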